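The compounds below may be only part of what the source reports. "The series", "measured", "known", "first", "only" and "open" are said of these compounds alone.

Among the compounds with values here, compound 1 `CN1CCC[C@H]1COc1cncc(O)c1` is the stronger of the two compounds measured so far. In an assay on HEK293 cells for displacement of a labelled ligand from Neuronal acetylcholine receptor; alpha3/beta4 (Homo sapiens), read by scintillation counting (a lower number here means a stronger inhibitor, a higher number a weaker inhibitor), compound 1 gives 235 nM, the lowest of the two numbers recorded, while compound 2 `COc1ccncc1OC[C@@H]1CCCN1` gives 2900 nM, a gap well beyond the usual scatter. Compound 3 `Oc1cncc(OC[C@@H]2CCCN2)c1` has not yet been measured. It differs from compound 1 by hydrogen in place of methyl on an amine nitrogen in a ring. Within the data shown here, no measured pair in this set isolates that single change, so the size of the step can only be guessed from the structures. The expected step from compound 1 to compound 3 is small, a 1.3-fold lower number from compound 1 to compound 3 (0.12 log units; within the scatter), with no change beyond the scatter as the most likely outcome. Compound 3 is therefore estimated at 180 nM, within a range from 50 nM to 650 nM.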

Compound 3, inhibition constant: 100 nM
Compound 3: middle estimate off by 1.8-fold (0.26 log units), on the high side; low and high end bracket the measured number.
By their numbers in this assay, from the lowest: compound 3; then compound 1; then compound 2.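

In this assay, hydrogen in place of methyl on the amine nitrogen of the five-membered non-aromatic ring gives a 2.4-fold lower number from compound 1 to compound 3 (0.37 log units; beyond the scatter) in a modest step that lies beyond the scatter. Within the data shown here, this is the first change in one place that can be read in this set, and it shows that the methyl on this nitrogen is not required for activity here, since compound 3, which lacks it, has the lower number. No measurement in hand explains why the number falls at this position.

The compounds shown leave open whether an ethyl group or a longer chain on this nitrogen would raise or lower the number. They also leave open whether the same change would have a step of similar size on a core carrying an amine in place of the hydroxyl group.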